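This account rests on a few compounds, and the source may have more. Where it says the series, first, only, none or still open, it means among the compounds named here.

Values in an ADME assay on microsomes from liver (Homo sapiens) for metabolic stability, read by LC-MS, tested at 1 uM (on this read-out higher numbers stand for fast clearance and lower numbers for slow clearance), for the measured compounds:
Compound 1 `NCCOc1ccc([C@H]2CC[C@]3(CC2)OOC2(O3)C3CC4CC(C3)CC2C4)cc1` gives < 7 mL.min-1.g-1 (a limit)
Compound 2 `c1cc([C@H]2CC[C@]3(CC2)OOC2(O3)C3CC4CC(C3)CC2C4)ccc1OCCOC1CCNCC1` gives < 7 mL.min-1.g-1 (a limit)
Compound 3 `CC(C)(O)CNCCCOc1ccc([C@H]2CC[C@]3(CC2)OOC2(O3)C3CC4CC(C3)CC2C4)cc1` gives 8 mL.min-1.g-1 (a number)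

Among the compounds with values here, compound 3 with 8 mL.min-1.g-1 holds the only true number of the three. Compound 1 and compound 2 give only a limit (the limit of < 7 mL.min-1.g-1 in this assay, at which 2 of the 3 values shown sit). Compound 4 `c1cc([C@H]2CC[C@]3(CC2)OOC2(O3)C3CC4CC(C3)CC2C4)ccc1OCCC1CCNCC1` carries piperidin-4-yl in place of ((2-hydroxy-2-methylpropyl)amino)methyl on a saturated chain carbon, two bonds along the chain from an oxygen on an aromatic ring. Within the data shown here, two steps bear on it (an at least 1.1-fold higher number from compound 2 to compound 3 (0.05 log units; that floor lies within the scatter)) and (an at least 1.1-fold higher number from compound 1 to compound 3 (0.05 log units; that floor lies within the scatter)), both with floors within the scatter. The third (a step that the two limits leave unreadable from compound 1 to compound 2) gives no size. So in this assay no step beyond the scatter is expected, in either direction. For compound 4 the estimated step is (a 1.1-fold lower number from compound 3 to compound 4 (0.06 log units; within the scatter)), none beyond the scatter. Compound 4 is expected at 7 mL.min-1.g-1 with an estimated range from 4 mL.min-1.g-1 to 14 mL.min-1.g-1 in this measurement.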

Compound 4, intrinsic clearance in microsomes: < 7 mL.min-1.g-1
Compound 4 ended at the assay's limit (the forecaster's own chance of this, stated with the estimate: 55%); the middle value lies on the limit itself.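

In this assay compound 4 also gives only a limit, so piperidin-4-yl on this saturated chain carbon joins amino and (piperidin-4-yl)oxy there: the limit of < 7 mL.min-1.g-1 in this assay, at which 3 of the 4 values shown sit.

Set against ((2-hydroxy-2-methylpropyl)amino)methyl, this change gives an at least 1.1-fold lower number from compound 3 to compound 4 (0.05 log units; that floor lies within the scatter), so no change beyond the scatter is shown. The steps to compound 4 from compound 1 and from compound 2 join two limits and cannot be read.

Going by these compounds, how far the three limit compounds differ among themselves stays open. So does whether a carboxylic acid or a longer chain at this place would give a true number in this assay.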